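Swapping thiophen-2-yl for furan-2-yl on the chain

This account rests on a few compounds, and the source may have more. Where it says the series, first, only, none or still open, it means among the compounds named here.

Measured so far:
Compound 1 `O=C(/C=C/c1cccs1)c1cc(O)c(O)c([N+](=O)[O-])c1` gives 62900 nM.
Compound 2 `CC(=O)N1N=C(c2cc(O)c(O)c([N+](=O)[O-])c2)CC1c1nccs1` gives 68200 nM.

Working notes. In an assay on isolated protein for inhibition of Amine oxidase [flavin-containing] B (Homo sapiens), read by fluorescence (a lower number here means a stronger inhibitor, a higher number a weaker inhibitor), compound 1 stands at the lowest of the two numbers, but compound 2 lies within the usual scatter of it, so the two measured compounds cannot be told apart. Going by the values given here, no pair among the measured compounds differs in a single place, so no measured step is available to lean on.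

Compound 3 `O=C(/C=C/c1ccco1)c1cc(O)c(O)c([N+](=O)[O-])c1` is the next compound to be measured. It differs from compound 1 by furan-2-yl in place of thiophen-2-yl on a double-bonded chain carbon bound to a double-bonded chain carbon. Both measured compounds carry the same catechol-nitro core, and neither tells anything about exchanging one five-membered aromatic ring for another at this position. The expected step from compound 1 to compound 3 in this assay is therefore none beyond the scatter, a 1.0-fold higher number from compound 1 to compound 3 (0.00 log units; within the scatter). Compound 3 is estimated at 63000 nM, with a range from 30000 nM to 130000 nM.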

Compound 3, half-maximal inhibitory concentration: 68200 nM
Compound 3: the middle estimate sits 1.1-fold (0.03 log units) below what was measured; the range from low to high includes it.
By their numbers in this assay, from the lowest: compounds 1, 2 and 3 (each within the scatter of the next).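

In this assay, furan-2-yl in place of thiophen-2-yl on a double-bonded chain carbon bound to a double-bonded chain carbon gives a 1.1-fold higher number from compound 1 to compound 3 (0.04 log units; within the scatter). Going by these compounds alone, this is the first single-place comparison, and it shows that the two five-membered aromatic rings, one with sulfur and one with oxygen as the hetero atom, cannot be told apart at this position. No measurement at hand gives a reason for this outcome.

The compounds shown leave open whether an amine or a carboxylic acid in place of the ring at this position would give a number beyond the scatter of these values. They also leave open whether a longer chain between the ring and the shared core would do so.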